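Compound 2 to compound 3: removing (6-hydroxyhexyl)oxy

This account rests on a few compounds, and the source may have more. Where it says the series, first, only, none or still open, it means among the compounds named here.

In a functional assay on FM3A cells (Mus musculus) for cytotoxicity (on this read-out higher numbers stand for an effect only at larger amounts of compound and lower numbers for an effect already at smaller amounts), compound 1 `CCOC(C)OOC1(OOC)CCCCCCCCCCC1` gives 12000 nM, and compound 2 `COOC1(OOCCCCCCO)CCCCCCCCCCC1` gives 1600 nM, the lower of the two numbers. Compound 3 `COOC1(OC)CCCCCCCCCCC1` carries methyl in place of (6-hydroxyhexyl)oxy on an oxygen on a saturated carbon. For the measured compounds named here, the only measured step bearing on this change is a 7.5-fold lower number from compound 1 to compound 2 (0.88 log units; beyond the scatter), with 6-hydroxyhexyl in place of 1-ethoxyethyl on an oxygen. Given that modest step, a move of similar size towards a higher number is expected in this assay, estimated as a 9.4-fold higher number from compound 2 to compound 3 (0.97 log units; beyond the scatter). For compound 3 the estimated value is 15000 nM, with an expected range from 3000 nM to 60000 nM.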

Compound 3, half-maximal effective concentration: 19000 nM
Estimate against measurement, compound 3: 1.3-fold (0.10 log units) below; the range from low to high includes it.
By their numbers in this assay, from the lowest: compound 2; then compounds 1 and 3 (each within the scatter of the next).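

In this assay, methyl in place of (6-hydroxyhexyl)oxy on an oxygen on a saturated carbon gives a 12-fold higher number from compound 2 to compound 3 (1.07 log units; beyond the scatter), so the lower number of compound 2 goes with that group. Methyl in place of 1-ethoxyethoxy gives a 1.6-fold higher number from compound 1 to compound 3 (0.20 log units; within the scatter), which sets (6-hydroxyhexyl)oxy alone among the three groups at this place. Nothing available explains these steps.

On these data alone, whether the terminal hydroxyl or the chain itself goes with the lower number remains open. A plain hexyl chain, a shorter hydroxyalkyl chain or a terminal carboxylic acid would bear on that question.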